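From methyl to methoxy on an aromatic carbon

The source may hold more compounds than are shown below. What is called first, only, known or untested is meant among the compounds shown, and "the series" means these compounds.

Compound 1 `COc1ccc(S(=O)(=O)c2nc3ccccc3nc2N2CCc3ccccc3C2)cc1` gives > 50000 nM (a limit of the assay)
Compound 2 `Cc1ccc(S(=O)(=O)c2nc3ccccc3nc2N2CCC(O)CC2)cc1` gives 4020 nM (a measured number)

For the measured compounds named here, in a functional assay on A549 cells (Homo sapiens) for cytotoxicity, read by MTT assay, with a stated time of 72 h (on this read-out lower numbers stand for stronger inhibition and higher numbers for weaker inhibition), compound 2 gives 4020 nM as the only actual number so far. Compound 1 reads > 50000 nM in this assay and that is a limit of the assay. Compound 3 `COc1ccc(S(=O)(=O)c2nc3ccccc3nc2N2CCC(O)CC2)cc1` has not yet been measured. It departs from compound 2 in one place: methoxy in place of methyl on an aromatic carbon (methoxy in place of methyl on an aromatic carbon, para to a large group). Going by the values given here, no measured step covers this change, so no shift beyond the scatter is expected in this assay. The estimated step runs a 1.1-fold lower number from compound 2 to compound 3 (0.06 log units; within the scatter) in this expectation. Compound 3 is expected at 3500 nM (estimated range 1300 nM to 10000 nM) in this assay.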

Compound 3, half-maximal inhibitory concentration: 5110 nM
Beside the measured number, compound 3's estimate is 1.5-fold (0.16 log units) below it; the measured number falls inside the stated range.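

In this assay methoxy in place of methyl on the aromatic carbon para to a large group gives a 1.3-fold higher number from compound 2 to compound 3 (0.10 log units; within the scatter) and so shows that this single change leaves the number within the scatter in this pair. Placing 4-hydroxypiperidin-1-yl in place of 1,2,3,4-tetrahydroisoquinolin-2-yl gives an at least 9.7-fold lower number from compound 1 to compound 3 (0.99 log units; beyond the scatter) and so provides the first step beyond the scatter. The value of compound 1 is a limit of the assay: the limit of > 50000 nM in this assay, at which 1 of the 3 values shown sits.

The compounds shown leave open whether a chlorine atom or an ethoxy group on this aromatic carbon would shift the number beyond the scatter. They also leave open how a morpholine ring would compare with 4-hydroxypiperidin-1-yl.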